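This account rests on a few compounds, and the source may have more. Where it says the series, first, only, none or still open, it means among the compounds named here.

The measured compounds:

compound 1, `Nc1ccc(SCC(=O)Nc2ccc3nc(NC(=O)c4ccc(C(F)(F)F)cc4)sc3c2)cc1`, 100 nM
compound 2, `Oc1ccc(Cl)cc1/C=N/c1ccc(-c2nc3ccccc3o2)c(O)c1`, 20100 nM
compound 3, `O=C(CSc1ccc(Cl)cc1)Nc1ccc2nc(NC(=O)c3ccc4ccccc4c3)sc2c1`, 4040 nM

All three were tested in a functional assay on HCT-116 cells (Homo sapiens) for antiproliferative activity, read by MTT assay, with a stated time of 72 h; on this read-out lower numbers stand for stronger inhibition and higher numbers for weaker inhibition. Compound 1 gives the lowest of the three numbers, so on this read-out it is the strongest inhibitor of the set. The nearest of the others is compound 3, whose number is higher by a margin well beyond the usual scatter, and compound 2 lies further still. Compound 2 shares nothing of the core of compound 1, whereas compound 3 keeps that core and differs in more than one place, so neither pair offers a single clean step to learn from.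

The unmeasured compound 4, `O=C(CSc1nc2ccccc2[nH]1)Nc1ccc2nc(NC(=O)c3ccc(C(F)(F)F)cc3)sc2c1`, differs from compound 1 in one place: 1H-benzimidazol-2-yl in place of 4-aminophenyl on a sulfur. The sulfur that carries the group keeps its other neighbour, the saturated chain carbon, and everything else is unchanged. Going by the values given here, no measured pair shows what this exchange does, so the expectation rests on compound 1 alone. The expected step of a 2.5-fold higher number from compound 1 to compound 4 (0.40 log units; beyond the scatter) is small and towards a somewhat higher number, though it could fall within the scatter. Compound 4 is therefore expected to give about 250 nM, within a range from 50 nM to 1500 nM.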

Compound 4, half-maximal inhibitory concentration: 3760 nM
The estimate for compound 4 lay 15-fold (1.18 log units) below the measured number; measured number above the stated range.
By their numbers in this assay, from the lowest: compound 1; then compounds 4 and 3 (each within the scatter of the next); then compound 2.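

In this assay the group on the sulfur turns out to matter a great deal: with 1H-benzimidazol-2-yl in place of 4-aminophenyl the result is a 38-fold higher number from compound 1 to compound 4 (1.58 log units; beyond the scatter) and this counts as a large step. Going by these compounds alone, the two groups have the same counts of hydrogen-bond donors and acceptors and neither carries a net charge, so those counts alone do not separate them here, and the earlier compounds offered no pair that differed at this position alone. With everything else held fixed, this single exchange is enough to lose most of the strength that compound 1 shows at 100 nM and nothing available here explains why the loss is so large.

The compounds shown leave open which part of 4-aminophenyl carries the benefit, the amine or the carbon ring, and a plain phenyl or a 4-hydroxyphenyl on the same sulfur would begin to separate the two. They also leave open whether a small group such as methyl on that sulfur would keep any of this activity, and whether the same exchange costs as much with a different group on the far amide of the shared core.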